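Swapping Isopropyl for 2-Fluorobenzyl on the Oxygen

The source may hold more compounds than are shown below. What is called first, only, known or untested is meant among the compounds shown, and "the series" means these compounds.

compound 1 `CCOC(=O)c1c(C)nc(-c2ccc(C#N)cc2)n1OC`: 13400 nM
compound 2 `CCOC(=O)c1c(C)nc(-c2ccccc2)n1OC`: > 30000 nM
compound 3 `CCOC(=O)c1c(C)nc(-c2cccc(C#N)c2)n1OC(C)C`: 6740 nM

Three measured compounds share one core and differ in the group on the oxygen and in the substituent on the aryl ring. In a functional assay on a cell-free system (plasma, Oryctolagus cuniculus) for inhibition, with stated times of 5 min, 1 min and 6 min (a lower number here means a stronger inhibitor, a higher number a weaker inhibitor), compound 1 gives 13400 nM. Compound 2 reaches only a limit of this assay, > 30000 nM (the limit of > 30000 nM in this assay, at which 1 of the 3 values shown sits). Compound 3 gives 6740 nM, the lower of the two numbers, with compound 1 as its nearest neighbour at a gap within the usual scatter. For the measured compounds named here, the single measured step, an at least 2.2-fold higher number from compound 1 to compound 2 (0.35 log units; beyond the scatter), concerns hydrogen in place of cyano on an aromatic carbon and says nothing about the oxygen substituent. Compound 1 and compound 3 differ in two places at once, so their two values alone show no isolated effect of the group on the oxygen.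

Compound 4 `CCOC(=O)c1c(C)nc(-c2cccc(C#N)c2)n1OCc1ccccc1F` differs from compound 3 by 2-fluorobenzyl in place of isopropyl on an oxygen on an aromatic ring. Going by the values given here, no measured step bears on this change, so no direction is expected beyond the scatter, and the estimate rests on compound 3 at 6740 nM. Compound 4 is expected to give 5000 nM, between 1200 nM and 20000 nM, an estimated step of a 1.3-fold lower number from compound 3 to compound 4 (0.13 log units; within the scatter).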

Compound 4, half-maximal inhibitory concentration: 8990 nM
For compound 4 the middle estimate is 1.8-fold (0.25 log units) below the measured one; low and high end bracket the measured number.
By their numbers in this assay, from the lowest: compounds 3, 4 and 1 (each within the scatter of the next). At a limit, above all of these: compound 2.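

For the compounds shown here, compound 3 and compound 4 differ in one place only, so this pair gives the first isolated reading of the group on the oxygen. In this assay the exchange of isopropyl for 2-fluorobenzyl gives a 1.3-fold higher number from compound 3 to compound 4 (0.13 log units; within the scatter) and so leaves the two numbers within the scatter of each other, even though a group of 8 heavy atoms with an aromatic ring replaces one of 3 heavy atoms with no ring. Nothing at hand bears on why this exchange reads as it does.

Open, as far as these compounds go, is how a plain benzyl group would read, which would separate the ring from the fluorine, and how a chain ending in an amine or a carboxylic acid would read at the same oxygen. Also open, from the compounds shown here alone, is whether the same holds on the aryl ring of compound 1.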